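The compounds below may be only part of what the source reports. "The series", "measured", "known", "first", "only" and "open" are said of these compounds alone.

Of the compounds shown here, two built on a shared core have been tested in a functional assay, read by spectrophotometry, with a stated time of 15 min, tested at 40 ug/mL; on this read-out higher numbers stand for a stronger effect at the one concentration tested and lower numbers for a weaker effect. Compound 1 `Cc1ccc(-c2csc(N/N=C/c3ccc(Cl)cc3Cl)n2)cc1` gives 86.2%. Compound 2 `Fc1ccc(-c2csc(N/N=C/c3cccs3)n2)cc1` gives 93.3%. On the numbers shown, compound 1 carries the smaller of the two figures, yet the gap to compound 2 lies within the usual scatter of this kind of measurement, so neither compound can be called stronger than the other. Among the measured compounds shown here, no pair of measured compounds that differ in a single place is available, so nothing in the measured data shows how one substitution alone moves the read-out.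

Compound 3 `Clc1ccc(-c2csc(N/N=C/c3ccc(Cl)cc3Cl)n2)cc1` has not yet been measured. It differs from compound 1 in one place: chloro in place of methyl on an aromatic carbon. The place, on an aromatic carbon of a six-membered aromatic ring of carbon only, para to a large group, is the same in both compounds. For the measured compounds named here, with no measured step to lean on, the expected step of a number 0.2 percentage points lower from compound 1 to compound 3 (within the scatter) is taken to be none beyond the scatter, in either direction. Compound 3 is therefore expected to give about 86% in this assay, between 72% and 96%.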

Compound 3, a percentage reported as inhibition, at one concentration (the size of the read-out at that concentration, not a potency): 85.9%
The estimate for compound 3 lay 0.1 percentage points above the measured number; the range from low to high includes it.
By their numbers in this assay, from the lowest: compounds 3, 1 and 2 (each within the scatter of the next).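

Among the compounds shown here, compound 1 and compound 3 form the first pair that differs in one place, and in this assay the change from 4-methylphenyl to 4-chlorophenyl reads as a number 0.3 percentage points lower from compound 1 to compound 3 (within the scatter) on the otherwise unchanged core of compound 1. At this place, on an aromatic carbon para to a large group, methyl and chloro therefore cannot be told apart at the one concentration tested, which the two earlier compounds, differing in more than one place, could not show. No measured evidence available here bears on why the two groups read alike.

For the compounds shown here, what a different kind of group would do at this place stays open, for instance an amine, a carboxylic acid or a longer chain, since methyl and chloro are the only two groups compared here and neither says whether the read-out can move beyond the scatter. As far as these compounds go, compound 2 differs from compound 1 and compound 3 in more than one place, so it remains open whether chloro in place of methyl would read the same way with the rest of the molecule changed.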